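Five-membered azoles at the para position of compound 2

A few compounds are considered here, and "the series" means these few. Any claim that something is new, unique, unknown or untested is made for them only; others in the source may bear on it.

Compound 1 `CCC(C)(C)Cc1c[nH]c(CCc2ccc(-c3ccncc3)cc2)n1` — 305 nM in a functional assay on HEK293 cells for agonist activity at Bombesin receptor subtype-3 (Homo sapiens), read by luminescence and calcium flux, with a stated time of 10 min; on this read-out higher numbers stand for an effect only at larger amounts of compound and lower numbers for an effect already at smaller amounts
Compound 2 `CCC(C)(C)Cc1c[nH]c(CCc2ccc(-n3ncnn3)cc2)n1` — 422 nM in this assay
Compound 3 `CCC(C)(C)Cc1c[nH]c(CCc2ccc(-n3ccnn3)cc2)n1` — not yet measured

Of the compounds shown here, two sharing one core have been tested. In this assay compound 1 gives 305 nM, and compound 2 gives 422 nM, which is the highest of the two numbers, the step of a 1.4-fold higher number from compound 1 to compound 2 (0.14 log units; within the scatter) lying within the scatter. Compound 3 differs from compound 2 in one place: 1H-1,2,3-triazol-1-yl in place of 2H-tetrazol-2-yl on an aromatic carbon. Going by the values given here, the only measured step that bears on this change is the exchange of one ring for another at the same place, from compound 1 to compound 2, and that step did not move beyond the scatter. Both the leaving and the entering group here are small five-membered aromatic rings, so one would expect the number for compound 3 to stay close to that of compound 2, with the step of a 1.1-fold lower number from compound 2 to compound 3 (0.02 log units; within the scatter) estimated to lie within the scatter and with no clear direction. Compound 3 is therefore estimated at 400 nM, with a range from 180 nM to 900 nM.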

Compound 3, half-maximal effective concentration: 641 nM
For compound 3 the middle estimate is 1.6-fold (0.20 log units) below the measured one, within the range that was stated.
By their numbers in this assay, from the lowest: compounds 1, 2 and 3 (each within the scatter of the next, the first and the last beyond it).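

In this assay, exchanging 2H-tetrazol-2-yl for 1H-1,2,3-triazol-1-yl on the aromatic carbon gives a 1.5-fold higher number from compound 2 to compound 3 (0.18 log units; within the scatter) and so does not separate these two five-membered aromatic rings, one with 4 hetero atoms and the other with 3, at this place para to a large group. The comparison with the pyridin-4-yl group gives the first difference beyond the scatter in this set, a 2.1-fold higher number from compound 1 to compound 3 (0.32 log units; beyond the scatter) and this step is modest. Compound 2 lies within the scatter of both compound 1 and compound 3, so the three compounds span only a shallow range, and only the two ends can be told apart. Nothing available here explains these numbers.

All three compounds carry an aromatic ring at this place, so they leave open how a carboxylic acid, an amine or a longer chain there would read in this assay. Also open, going by these compounds, is whether another ring, such as 1H-imidazol-1-yl or phenyl, would stay within this narrow range.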